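The source may hold more compounds than are shown below. What is called first, only, known or untested is meant among the compounds shown, and "the series" means these compounds.

In a functional assay on LOX IMVI cells (Homo sapiens) for cytotoxicity, read by MTT assay, with a stated time of 24 h; on this read-out lower numbers stand for stronger inhibition and higher numbers for weaker inhibition:
- compound 1 `O=S(=O)(NCCCNc1nccc(-c2[nH]c(-c3ccccc3)nc2-c2ccc(F)c(O)c2)n1)c1ccc(F)cc1`: 19200 nM
- compound 2 `O=S(=O)(NCCCNc1nccc(-c2[nH]c(-c3ccccc3)nc2-c2ccc(F)c(O)c2)n1)c1ccc(C(F)(F)F)cc1`: 2450 nM
- compound 3 `Cc1ccc(S(=O)(=O)NCCCNc2nccc(-c3[nH]c(-c4ccccc4)nc3-c3ccc(F)c(O)c3)n2)cc1`: 26300 nM

Compound 3 stands at the high end of these numbers, level with compound 1 and well clear of compound 2. The steps show this: a 1.4-fold higher number from compound 1 to compound 3 (0.14 log units; within the scatter), against an 11-fold higher number from compound 2 to compound 3 (1.03 log units; beyond the scatter).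

Compound 4 `Cc1ccc(S(=O)(=O)NCCCNc2nccc(-c3[nH]c(-c4ccccc4)nc3-c3ccc(Cl)c(O)c3)n2)cc1` differs at one place: chloro in place of fluoro on an aromatic carbon. This reads 4-fluoro-3-hydroxyphenyl to 4-chloro-3-hydroxyphenyl. Among the compounds with values here, no measured step touches this place. The nearest guides are fluoro replacements elsewhere in the molecule: a 7.8-fold lower number from compound 1 to compound 2 (0.89 log units; beyond the scatter) and a 1.4-fold higher number from compound 1 to compound 3 (0.14 log units; within the scatter). They point to a small expected shift, leaning lower, and that expectation is a 1.9-fold lower number from compound 3 to compound 4 (0.27 log units; within the scatter). The estimate for compound 4 is 14000 nM, with an expected range of 4500 nM to 32000 nM.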

Compound 4, half-maximal inhibitory concentration: 6020 nM
Beside the measured number, compound 4's estimate is 2.3-fold (0.37 log units) above it, within the range that was stated.
By their numbers in this assay, from the lowest: compound 2; then compound 4; then compounds 1 and 3 (each within the scatter of the next).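

In this assay, chloro in place of fluoro gives a 4.4-fold lower number from compound 3 to compound 4 (0.64 log units; beyond the scatter), so this position, ortho to a hydroxy group, responds to a change of halogen. The earlier steps shown here all lay at another place in the molecule and could not show this. Nothing available here accounts for the shift. The compounds shown leave open how a bromo group or an amine would read at this position. They also leave open whether chloro here would lower the number in the same way with the trifluoromethyl group of compound 2 in place.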